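This account rests on a few compounds, and the source may have more. Where it says the series, first, only, none or still open, it means among the compounds named here.

Compounds 1, 2 and 3 share one core and differ only in the ester on the side chain: compound 1 `CC(=O)OCCc1c(-c2ccccc2Cl)c2cc(Cl)ccc2[nH]c1=O`, compound 2 `CCCC(=O)OCCc1c(-c2ccccc2Cl)c2cc(Cl)ccc2[nH]c1=O` and compound 3 `CC(=O)OCC(=O)OCCc1c(-c2ccccc2Cl)c2cc(Cl)ccc2[nH]c1=O`. In an ADME assay on HepG2 2.2.15 cells (Homo sapiens) for cytotoxicity (a lower number here means that less compound is tolerated, a higher number that more compound is tolerated), compound 1 gives 27000 nM, compound 2 gives 52000 nM and compound 3 gives 100000 nM, the highest of the three numbers; the step of a 3.7-fold higher number from compound 1 to compound 3 (0.57 log units; beyond the scatter) is modest, while a 1.9-fold higher number from compound 1 to compound 2 (0.28 log units; within the scatter) and a 1.9-fold higher number from compound 2 to compound 3 (0.28 log units; within the scatter) stay within the scatter. Compound 4 `O=C(OCCc1c(-c2ccccc2Cl)c2cc(Cl)ccc2[nH]c1=O)c1cccnc1` carries a different ester: pyridin-3-yl in place of acetoxymethyl on a carbonyl carbon. Within the data shown here, no measured step touches the carbonyl carbon itself, so the expectation rests on the narrow spread of the three esters so far, and the step of a 1.7-fold lower number from compound 3 to compound 4 (0.22 log units; within the scatter) is expected to stay within the scatter or fall slightly. For compound 4 the estimated value in this assay is 60000 nM, within 25000 nM to 150000 nM.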

Compound 4, half-maximal cytotoxic concentration: 170000 nM
Beside the measured number, compound 4's estimate is 2.8-fold (0.45 log units) below it; the measured number lies above the stated range.
By their numbers in this assay, from the lowest: compounds 1, 2, 3 and 4 (each within the scatter of the next, the first and the last beyond it).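

In this assay, the carbonyl carbon accepts a six-membered aromatic ring: pyridin-3-yl in place of methyl gives a 6.3-fold higher number from compound 1 to compound 4 (0.80 log units; beyond the scatter) and in place of propyl gives a 3.3-fold higher number from compound 2 to compound 4 (0.51 log units; beyond the scatter), both modest. Against acetoxymethyl, the same ring gives a 1.7-fold higher number from compound 3 to compound 4 (0.23 log units; within the scatter), so these two esters cannot be told apart here. No available data bear on the cause of these steps. Open, on these data alone, is whether the ring nitrogen matters, which phenyl on the carbonyl carbon would test. Also open, as far as these compounds go, is how an amine or a carboxylic acid on the ester would read.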